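Removing the Hydroxymethylphenyl Group from Compound 1

A few compounds are considered here, and "the series" means these few. Any claim that something is new, unique, unknown or untested is made for them only; others in the source may bear on it.

Measured so far in a functional assay on MGC-803 cells (Homo sapiens) for antiproliferative activity, read by CellTiter-Glo, with a stated time of 72 h (on this read-out higher numbers stand for weaker inhibition and lower numbers for stronger inhibition), are:
- compound 1 `O=C(NO)c1ccc(/C=C/c2ccnc(-c3cccc(CO)c3)c2)cc1` with 1740 nM
- compound 2 `O=C(NO)c1ccc(/C=C/c2cccc(-c3cccc(O)c3)c2)cc1` with 8820 nM

Among the compounds with values here, only these two compounds have numbers so far. Compound 1 stands lower, at 1740 nM against compound 2 at 8820 nM in the same read-out, and that gap lies beyond the usual scatter. Compound 1 is therefore the stronger inhibitor of this pair.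

The next compound is compound 3 `O=C(NO)c1ccc(/C=C/c2ccncc2)cc1` and it has not yet been measured. It differs from compound 1 by hydrogen in place of 3-(hydroxymethyl)phenyl on an aromatic carbon and this carbon lies next to the ring nitrogen.

Within the data shown here, no measured pair isolates this change, so the data give no direct guide to its size. Compound 1 holds the lower number (1740 nM) and so a change this large seems more likely to raise the number than to lower it. In this assay a moderate loss of inhibition is expected, beyond the scatter, with the estimated step of a 2.9-fold higher number from compound 1 to compound 3 (0.46 log units; beyond the scatter) as its size. Compound 3 is estimated at 5000 nM (expected range 1500 nM to 20000 nM).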

Compound 3, half-maximal inhibitory concentration: 3930 nM
Estimate against measurement, compound 3: 1.3-fold (0.10 log units) above; low and high end bracket the measured number.
By their numbers in this assay, from the lowest: compound 1; then compound 3; then compound 2.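

In this assay, within the data shown here, replacing the 3-(hydroxymethyl)phenyl group with hydrogen on this aromatic carbon next to the ring nitrogen gives a 2.3-fold higher number from compound 1 to compound 3 (0.35 log units; beyond the scatter) and so provides the first direct reading of this position. The step is modest but beyond the scatter: compound 3, with hydrogen on this carbon, still gives a measurable number in this assay, so the activity does not depend entirely on the 3-(hydroxymethyl)phenyl group, although the group's presence in compound 1 goes with stronger inhibition. Nothing in the available data explains the size of this step.

The compounds shown leave open whether the difference follows the phenyl ring itself or the hydroxymethyl group on it, and how a smaller group on this carbon, such as methyl or an amine, would compare with hydrogen. They also do not isolate the role of the ring nitrogen, since compound 2 differs from compound 1 in more than one place.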